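The source may report more compounds than this note shows. Statements on the series, on what has been measured and on what is new or still open speak of the compounds shown alone.

Measured compounds:
compound 1, `FC(F)(F)c1ccc(CSc2nc(Nc3ccccc3Cl)c3ccccc3n2)cc1`, 20400 nM
compound 2, `FC(F)(F)c1ccc(CSc2nc(Nc3cccc(C(F)(F)F)c3)c3ccccc3n2)cc1`, 12900 nM
compound 3, `CCOc1ccc(Nc2nc(SCc3ccc(C(F)(F)F)cc3)nc3ccccc23)cc1`, 32100 nM

All three were tested in a functional assay on PC-3 cells (Homo sapiens) for cytotoxicity, read by MTT assay, with a stated time of 72 h (on this read-out lower numbers stand for stronger inhibition and higher numbers for weaker inhibition), and all three share one core, differing only in the aryl group carried on a nitrogen on an aromatic ring. Compound 3 gives the highest number of the three: one of the steps leading to it stays within the scatter (a 1.6-fold higher number from compound 1 to compound 3 (0.20 log units; within the scatter)) and the other goes beyond it (a 2.5-fold higher number from compound 2 to compound 3 (0.40 log units; beyond the scatter)).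

Compound 4, `COc1ccc(Nc2nc(SCc3ccc(C(F)(F)F)cc3)nc3ccccc23)c(OC)c1`, has not yet been measured. It differs from compound 3 by 2,4-dimethoxyphenyl in place of 4-ethoxyphenyl on a nitrogen on an aromatic ring. The three measured steps all exchange this same aryl group: a 1.6-fold lower number from compound 1 to compound 2 (0.20 log units; within the scatter), a 1.6-fold higher number from compound 1 to compound 3 (0.20 log units; within the scatter) and a 2.5-fold higher number from compound 2 to compound 3 (0.40 log units; beyond the scatter). Two of them stay within the scatter and the third is only modest, so the aryl group on this nitrogen moves the number little across the compounds seen so far. Compound 4 is therefore expected to land near compound 3, with a step of about a 1.1-fold lower number from compound 3 to compound 4 (0.06 log units; within the scatter) and no clear direction. The estimated value for compound 4 in this assay is 28000 nM, with a likely range from 11000 nM to 70000 nM.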

Compound 4, half-maximal inhibitory concentration: 32500 nM
Compound 4: middle estimate off by 1.2-fold (0.06 log units), on the low side; low and high end bracket the measured number.
By their numbers in this assay, from the lowest: compounds 2, 1, 3 and 4 (each within the scatter of the next, the first and the last beyond it).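

In this assay, a second oxygen-bearing aryl group leaves the number where it was: 2,4-dimethoxyphenyl in place of 4-ethoxyphenyl, with one more methoxy-type oxygen and one more heavy atom, gives (a 1.0-fold higher number from compound 3 to compound 4 (0.01 log units; within the scatter)). Compound 4 also repeats the gap already seen for compound 3 against the 3-(trifluoromethyl)phenyl compound (a 2.5-fold higher number from compound 2 to compound 4 (0.40 log units; beyond the scatter)), and it stays within the scatter of the 2-chlorophenyl compound (a 1.6-fold higher number from compound 1 to compound 4 (0.20 log units; within the scatter)), so the two oxygen-bearing aryl groups stand together only against compound 2. Nothing at hand explains these numbers.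

From the compounds shown here alone, whether an aryl group carrying an amine or a carboxylic acid would move the number further remains open. So does what a longer alkyl chain on this nitrogen, in place of the aryl group, would do.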